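Swapping methoxy for chloro on a triazole antiproliferative

This account rests on a few compounds, and the source may have more. Where it says the series, first, only, none or still open, it means among the compounds named here.

Of the compounds shown here, two built on the same core have been tested in a functional assay on K562 cells (Homo sapiens) for antiproliferative activity, read by MTT assay, with a stated time of 72 h; a higher number here means a weaker inhibitor, a lower number a stronger inhibitor. Compound 1 `COc1ccc(-n2ncnc2-c2cc(OC)c(OC)c(OC)c2)cc1` gives 3600 nM, the higher of the two numbers and therefore the weaker inhibitor of the pair. Compound 2 `COc1cc(-n2ncnc2-c2ccc(SC)cc2)cc(OC)c1OC` gives 340 nM, a clearly lower number, lying well beyond the usual scatter of this assay; since the two compounds differ in more than one place, that gap cannot be traced to a single change.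

Compound 3 `COc1cc(-c2ncnn2-c2ccc(Cl)cc2)cc(OC)c1OC` has not yet been measured. It differs from compound 1 in one place only: chloro in place of methoxy on an aromatic carbon. Chloro replaces methoxy on an aromatic carbon of a six-membered aromatic ring of carbon only, and nothing else moves.

Among the compounds with values here, no measured pair shows this particular exchange, so there is no measured step to lean on. The expectation is a modest move, if any, toward a lower number, of a size that may not rise beyond the scatter: the estimated step is a 1.8-fold lower number from compound 1 to compound 3 (0.26 log units; within the scatter). On that basis compound 3 is expected to give about 2000 nM in this assay, with a likely range from 600 nM to 6500 nM.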

Compound 3, half-maximal inhibitory concentration: > 10000 nM
Compound 3: no number, only a limit; the forecaster's own chance of this, stated with the estimate: 3%; at least 5.0-fold (0.69 log units) between middle value and limit.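

In this assay compound 3 gives > 10000 nM, which is a limit and not a number. Even so, it gives this position its first readable single change, and that change costs activity: chloro in place of methoxy, para to a large group, brings an at least 2.7-fold higher number from compound 1 to compound 3 (0.44 log units; beyond the scatter), a step beyond the scatter. On this core, then, the 4-methoxyphenyl cannot be exchanged for 4-chlorophenyl without loss, although only a single small group differs, but the printed step is a minimum rather than a measured size, because the reading of compound 3 ends at a limit: the limit of > 10000 nM in this assay, at which 1 of the 3 values shown sits.

A single exchange cannot tell whether the loss comes from removing methoxy or from introducing chloro, and it cannot show whether the same exchange would behave alike on any other core. As far as these compounds go, how a hydroxyl, a methyl or an amine at this same place would read in this assay remains open, and such groups would help separate those two possibilities.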